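Sulfonamide nitrogen swap: compound 2 to compound 3

A few compounds are considered here, and "the series" means these few. Any claim that something is new, unique, unknown or untested is made for them only; others in the source may bear on it.

Among the measured compounds shown here, in a functional assay on MCF7 cells (Homo sapiens) for antiproliferative activity, read by MTT assay, with a stated time of 72 h (on this read-out higher numbers stand for weaker inhibition and lower numbers for stronger inhibition), compound 1 (`COc1cccc(N(C)S(=O)(=O)C2CC3OC2C(c2ccc(NC(=O)CCCCCCC(=O)O)cc2)=C3c2ccc(O)cc2)c1`) gives 39400 nM and compound 2 (`CN(c1ccccc1Cl)S(=O)(=O)C1CC2OC1C(c1ccc(NC(=O)CCCCCCC(=O)O)cc1)=C2c1ccc(O)cc1`) gives 12800 nM as the lower of the two numbers so far. Compound 3 (`CCN(c1ccccc1)S(=O)(=O)C1CC2OC1C(c1ccc(NC(=O)CCCCCCC(=O)O)cc1)=C2c1ccc(O)cc1`) has ethyl(phenyl)amino in place of (2-chlorophenyl)(methyl)amino on a sulfonyl sulfur and keeps the shared core. For the measured compounds named here, one measured step bears on this change: a 3.1-fold lower number from compound 1 to compound 2 (0.49 log units; beyond the scatter) is modest and beyond the scatter, with 2-chlorophenyl in place of 3-methoxyphenyl on a sulfonamide nitrogen. Going by the values given here, no measured compound carries ethyl on this nitrogen or an unsubstituted phenyl, so the evidence is thin. The expected step is small and toward a higher number, estimated as a 1.6-fold higher number from compound 2 to compound 3 (0.19 log units; within the scatter) in this series. Compound 3 is expected near 20000 nM with an estimated range of 8000 nM to 50000 nM in this assay for now.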

Compound 3, half-maximal inhibitory concentration: 19100 nM
Compound 3: the middle estimate sits 1.0-fold (0.02 log units) above what was measured; measured number inside the range.
By their numbers in this assay, from the lowest: compounds 2 and 3 (each within the scatter of the next); then compound 1.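

The measure this assay shows a 1.5-fold higher number from compound 2 to compound 3 (0.17 log units; within the scatter) when ethyl(phenyl)amino stands in place of (2-chlorophenyl)(methyl)amino, so these two groups on the sulfonyl sulfur cannot be told apart here. Compound 3 carries an ethyl and an unsubstituted phenyl, and the step of a 2.1-fold lower number from compound 1 to compound 3 (0.31 log units; beyond the scatter) shows that a number lower than that of compound 1 is reached without a chlorine on the ring. Nothing available accounts for these differences in terms of mechanism or property.

The change from compound 2 to compound 3 alters the nitrogen's alkyl group and the ring together, so the contribution of each remains unresolved. Also open, on these data alone, is whether a propyl on this nitrogen, or a pyridine ring in place of the phenyl, would stay in this range.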